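Swapping a Bulky Aryl Group for 4-Fluorophenyl

The compounds below may be only part of what the source reports. "The series", "measured", "known", "first", "only" and "open" are said of these compounds alone.

Measured so far in a functional assay on MIA PaCa-2 cells (Homo sapiens) for inhibition, read by MTT assay, with a stated time of 48 h, tested at 10 uM; a higher number here means more inhibition of growth at the concentration tested, a lower number less inhibition of growth:
- compound 1 `Cc1oc2c([C@H]3CCN(C)C[C@H]3O)c(O)cc(O)c2c(=O)c1C(O)c1ccc(Cl)cc1`: 15%
- compound 2 `CCOc1ccc(Br)c(C(O)c2c(C)oc3c([C@H]4CCN(C)C[C@H]4O)c(O)cc(O)c3c2=O)c1`: 4%

Compound 2, at 4%, is the lower of these two values. Compound 3 `Cc1oc2c([C@H]3CCN(C)C[C@H]3O)c(O)cc(O)c2c(=O)c1C(O)c1ccc(F)cc1` places 4-fluorophenyl in place of 2-bromo-5-ethoxyphenyl on the same saturated chain carbon (4-fluorophenyl in place of 2-bromo-5-ethoxyphenyl on a saturated chain carbon bound to an aromatic carbon and an oxygen on a saturated carbon). Among the compounds with values here, one measured step bears on this change, at that same place: a number 11 percentage points lower from compound 1 to compound 2 (beyond the scatter). Compound 3 has a halogen-bearing phenyl, as does compound 1 at 15%, so a modest rise of similar size is expected in this assay. The expected step is a number 11 percentage points higher from compound 2 to compound 3 (beyond the scatter). Compound 3 is estimated at 15%, with an expected range of 4% to 30%.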

Compound 3, percent growth inhibition at one concentration: 17%
Beside the measured number, compound 3's estimate is 2 percentage points below it; low and high end bracket the measured number.
By their numbers in this assay, from the lowest: compound 2; then compounds 1 and 3 (each within the scatter of the next).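

In this assay 4-fluorophenyl recovers what 2-bromo-5-ethoxyphenyl lost on this saturated chain carbon, with a number 13 percentage points higher from compound 2 to compound 3 (beyond the scatter) as the step. Fluoro in place of chloro on an aromatic carbon gives a number 2 percentage points higher from compound 1 to compound 3 (within the scatter) and so the 4-chlorophenyl and 4-fluorophenyl compounds read alike, while compound 2 stands apart from both. Nothing measured here explains this difference. Going by these compounds, compound 2 carries bromo and ethoxy together, so the separate share of each stays open. Also open, on these data alone, is how a phenyl bearing an amine or a carboxylic acid would read at this place.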